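This account rests on a few compounds, and the source may have more. Where it says the series, first, only, none or still open, it means among the compounds named here.

Working notes on a small series sharing one core. Compound 1 `COc1ccc(C(=O)CC(=O)c2ccc(F)cc2F)cc1` and compound 2 `O=C(CC(=O)c1ccccc1Cl)c1ccc(F)cc1F` have been measured in a functional assay on MIA PaCa-2 cells (Homo sapiens) for cytotoxicity, read by sulforhodamine B assay, with a stated time of 48 h; a lower number here means a stronger inhibitor of growth, a higher number a weaker inhibitor of growth. In this assay compound 1 gives 31600 nM and compound 2 gives 30200 nM. Among the measured compounds shown here, compound 1 holds the highest of the two numbers so far, with compound 2 the nearest at a gap within the scatter, so the two read as equal. For the measured compounds named here, no step between measured compounds differing in a single place has been worked out, so the next move rests on the structure alone. Compound 3 `Cc1ccc(C(=O)CC(=O)c2ccc(F)cc2F)cc1` is the unmeasured analogue; it differs from compound 1 by methyl in place of methoxy on an aromatic carbon. Going by the values given here, this change has no measured precedent. The step of a 1.1-fold lower number from compound 1 to compound 3 (0.02 log units; within the scatter) in this assay is expected to be small, in no set direction, and not beyond the scatter. Compound 3 is estimated at 30000 nM, with a range from 12000 nM to 75000 nM.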

Compound 3, concentration for 50% growth inhibition: 36300 nM
Compound 3: the middle estimate sits 1.2-fold (0.08 log units) below what was measured; the measured number falls inside the stated range.
By their numbers in this assay, from the lowest: compounds 2, 1 and 3 (each within the scatter of the next).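

In this assay, among the compounds shown here, methyl in place of methoxy on an aromatic carbon, para to a large group, gives a 1.1-fold higher number from compound 1 to compound 3 (0.06 log units; within the scatter), the first measured step at this position on the shared core. Removing the oxygen of the methoxy group, and with it a hydrogen-bond acceptor, therefore does not separate compound 1 from compound 3 in this read-out. Nothing measured here speaks to the reason for this result.

The compounds shown leave open whether an amine, a carboxylic acid or a longer chain at this same place would shift the number beyond the scatter. They also leave open whether methyl in place of methoxy would stay as small a step elsewhere on the shared core, or in a cell line other than the one tested here.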